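Replacing the iodophenyl tail with a pyridyl ring

A few compounds are considered here, and "the series" means these few. Any claim that something is new, unique, unknown or untested is made for them only; others in the source may bear on it.

Compound 3 `O=c1[nH]/c(=N\OCCCc2ccc(I)cc2)ccn1[C@@H]1O[C@H](COP(=O)(O)OP(=O)(O)OP(=O)(O)O)[C@@H](O)[C@H]1O` gives the lowest of the three numbers in a functional assay on 1321-N1 cells for agonist activity at P2Y purinoceptor 2 (Homo sapiens), read by scintillation counting and inositol phosphate accumulation (a lower number here means that less compound is needed, a higher number that more compound is needed for the effect), 187 nM. Compound 2 `O=c1[nH]/c(=N\OCCCc2ccc(Br)cc2)ccn1[C@@H]1O[C@H](COP(=O)(O)OP(=O)(O)OP(=O)(O)O)[C@@H](O)[C@H]1O` gives 350 nM in this assay, and compound 1 `O=c1[nH]/c(=N\OCCCc2ccc(F)cc2)ccn1[C@@H]1O[C@H](COP(=O)(O)OP(=O)(O)OP(=O)(O)O)[C@@H](O)[C@H]1O` gives 547 nM. The measured steps are a 1.6-fold lower number from compound 1 to compound 2 (0.19 log units; within the scatter), a 1.9-fold lower number from compound 2 to compound 3 (0.27 log units; within the scatter) and a 2.9-fold lower number from compound 1 to compound 3 (0.47 log units; beyond the scatter); only the last lies beyond the scatter, so compound 3 stands apart from compound 1 but not from compound 2.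

Compound 4 `O=c1[nH]/c(=N\OCCCc2ccncc2)ccn1[C@@H]1O[C@H](COP(=O)(O)OP(=O)(O)OP(=O)(O)O)[C@@H](O)[C@H]1O` is not yet measured. It changes (pyridin-4-yl in place of 4-iodophenyl on a saturated chain carbon, three bonds along the chain from an oxygen). For the measured compounds named here, no measured step exchanges the halogen-bearing ring for a ring with a hetero atom; all three swap one halogen for another on the same ring, and the largest of them, a 2.9-fold lower number from compound 1 to compound 3 (0.47 log units; beyond the scatter), is modest. Here the halogen is dropped altogether and a nitrogen enters the ring, so the only guide is the direction of a 2.9-fold lower number from compound 1 to compound 3 (0.47 log units; beyond the scatter), which runs toward the heavier halogen. A higher number for compound 4 is therefore expected, by roughly a 4.3-fold higher number from compound 3 to compound 4 (0.63 log units; beyond the scatter), with wide uncertainty. Compound 4 is estimated at 800 nM in this assay, within 250 nM to 3000 nM.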

Compound 4, half-maximal effective concentration: 285 nM
Compound 4: the middle estimate sits 2.8-fold (0.45 log units) above what was measured; the measured number falls inside the stated range.
By their numbers in this assay, from the lowest: compounds 3, 4, 2 and 1 (each within the scatter of the next, the first and the last beyond it).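

In this assay, the ring on this saturated chain carbon accepts more than an exchange of one halogen for another: pyridin-4-yl, with no halogen and a ring nitrogen, stays within the scatter of all three halogenated compounds (a 1.5-fold higher number from compound 3 to compound 4 (0.18 log units; within the scatter); a 1.2-fold lower number from compound 2 to compound 4 (0.09 log units; within the scatter); a 1.9-fold lower number from compound 1 to compound 4 (0.28 log units; within the scatter)). The earlier steps shown here varied only the halogen on one ring, whereas compound 4 shows that neither a halogen nor an all-carbon ring is required for a number in this range. Nothing available explains why this larger exchange gives a step within the scatter.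

Compound 4 drops the iodine and brings in the nitrogen at once, and an unsubstituted phenyl ring would be needed to separate the two changes. On these data alone, whether pyridin-3-yl, pyridin-2-yl or a longer chain carrying the same ring would stay in this range also remains open.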